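Estimating Cytotoxicity for a Carbamoylethyl Analogue

A few compounds are considered here, and "the series" means these few. Any claim that something is new, unique, unknown or untested is made for them only; others in the source may bear on it.

Measured so far in a functional assay on HEL cells (Homo sapiens) for cytotoxicity, read by microscopy; on this read-out higher numbers stand for lower toxicity in this test and lower numbers for higher toxicity in this test:
compound 1 `CCOC(=O)NC(=O)NC1=CS(=O)(=O)O[C@@]12[C@@H](CO[Si](C)(C)C(C)(C)C)O[C@@H](n1cc(C)c(=O)n(C)c1=O)[C@@H]2O[Si](C)(C)C(C)(C)C` gives 16000 nM.
compound 2 `C=C(C)C(=O)NC(=O)NC1=CS(=O)(=O)O[C@@]12[C@@H](CO[Si](C)(C)C(C)(C)C)O[C@@H](n1cc(C)c(=O)n(C)c1=O)[C@@H]2O[Si](C)(C)C(C)(C)C` gives 20000 nM.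
compound 3 `Cc1cn([C@@H]2O[C@H](CO[Si](C)(C)C(C)(C)C)[C@@]3(OS(=O)(=O)C=C3NC(=O)c3ccccc3)[C@H]2O[Si](C)(C)C(C)(C)C)c(=O)n(C)c1=O` gives only a limit, >= 3200 nM.

Compound 1 holds the lowest of the two numbers, with compound 2 nearest: a 1.3-fold higher number from compound 1 to compound 2 (0.10 log units; within the scatter). Among the compounds with values here, compound 3 offers no usable step, since the limit of >= 3200 nM in this assay, at which 1 of the 3 values shown sits, leaves its distance from compound 1 unreadable.

Compound 4 `Cc1cn([C@@H]2O[C@H](CO[Si](C)(C)C(C)(C)C)[C@@]3(OS(=O)(=O)C=C3NCCC(N)=O)[C@H]2O[Si](C)(C)C(C)(C)C)c(=O)n(C)c1=O` differs from compound 1 by 2-carbamoylethyl in place of (ethoxycarbonyl)carbamoyl on an amine nitrogen. Within the data shown here, no measured step touches the amine nitrogen; the only readable one, from compound 1 to compound 2, changes a carbonyl substituent and stays within the scatter. No shift beyond the scatter is therefore expected for compound 4, no change at the digits printed from compound 1 to compound 4 (within the scatter). Compound 4 is estimated at 16000 nM, between 5000 nM and 50000 nM.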

Compound 4, minimum cytotoxic concentration: >= 80000 nM
Compound 4 gave a limit, no number (the forecaster's own chance of this, stated with the estimate: 30%); middle value at least 5.0-fold (0.69 log units) away from the limit.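

Within the data shown here, changing the group on the amine nitrogen moves the read-out in this assay beyond the scatter, which the one earlier readable step did not do: 2-carbamoylethyl in place of (ethoxycarbonyl)carbamoyl gives an at least 5.0-fold higher number from compound 1 to compound 4 (0.69 log units; beyond the scatter), and in place of ((1-methylethenyl)carbonyl)carbamoyl it gives an at least 4.0-fold higher number from compound 2 to compound 4 (0.60 log units; beyond the scatter), both towards lower toxicity in this test. Compound 4 gives only a limit, not a number: the limit of >= 80000 nM in this assay, at which 1 of the 4 values shown sits. The step from compound 3 to compound 4 cannot be read, as both values are limits. Still open, as far as these compounds go, is whether a carboxylic acid in place of the carbamoyl of 2-carbamoylethyl, or a longer chain on the amine nitrogen, would give a similar read-out.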